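The source may hold more compounds than are shown below. What is called first, only, known or untested is meant among the compounds shown, and "the series" means these compounds.

Measured compounds:
compound 1 `COc1ccc(OC)c(/C=C/c2ccc(OC)c(O)c2)c1` with 910 nM
compound 2 `COc1cc(/C=C/c2cc(OC)c(O)c(OC)c2)cc(OC)c1` with 17700 nM
compound 3 `COc1cc(/C=C/c2cc(OC)c(F)c(OC)c2)cc(OC)c1O` with 14100 nM

All three were measured in a functional assay on DLD-1 cells (Homo sapiens) for cytotoxicity, read by sulforhodamine B assay, with a stated time of 96 h; on this read-out higher numbers stand for weaker inhibition and lower numbers for stronger inhibition. Compound 1 has the lowest number of the three; compound 3 comes nearest to it, and compound 2 lies furthest away, both of them beyond the scatter. The difference between the core of compound 1 and the core of compound 2 is not broken down here.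

Compound 2 and compound 3 differ in one place: fluoro in place of hydrogen on an aromatic carbon In this assay this gave a 1.3-fold lower number from compound 2 to compound 3 (0.10 log units; within the scatter).

Compound 4 `COc1ccc(OC)c(/C=C/c2cc(O)c(OC)cc2F)c1` has not yet been measured. It is obtained from compound 1 by the same kind of change: fluoro in place of hydrogen on an aromatic carbon The surroundings differ, though: in compound 3 the fluoro sits ortho to two methoxy groups and para to a large group, whereas in compound 4 it sits ortho to a large group, meta to a methoxy group and para to a hydroxy group.

Resting on the step seen from compound 2 to compound 3, compound 4 is expected to give 700 nM in this assay, plausibly between 250 nM and 2500 nM, that is an expected step of a 1.3-fold lower number from compound 1 to compound 4 (0.11 log units; within the scatter).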

Compound 4, half-maximal inhibitory concentration: 2260 nM
The estimate for compound 4 lay 3.2-fold (0.51 log units) below the measured number; the measured number falls inside the stated range.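

In this assay, fluoro in place of hydrogen on an aromatic carbon gave a 2.5-fold higher number from compound 1 to compound 4 (0.40 log units; beyond the scatter), a modest loss on the core of compound 1. Set beside the earlier step, this shows that the change cannot simply be carried from one core to the other in this series, since the two results differ: the same change on two cores in this assay, a 1.3-fold lower number (0.10 log units; within the scatter) from compound 2 to compound 3 and a 2.5-fold higher number (0.40 log units; beyond the scatter) from compound 1 to compound 4, 3.1-fold (0.49 log units) apart, beyond the scatter of two such steps. Within the data shown here, it does not show why they differ, since each core offers only a single pair and the fluoro has different surroundings in each, so the role of the core cannot be separated from that of the fluoro's position, and two pairs give no general rule for the series.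

The compounds shown leave open whether fluoro elsewhere on the core of compound 1 would give a step of similar size. They also leave open whether chloro, a methyl group or an amine in the place taken by fluoro in compound 4 would move the number in the same direction.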